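The compounds below may be only part of what the source reports. "The series", "measured", "known", "first", "only" and "open" are said of these compounds alone.

Of the compounds shown here, two have been tested in an assay on cells for inhibition of Polyunsaturated fatty acid 5-lipoxygenase (Rattus norvegicus), tested at 5 uM (on this read-out lower numbers stand for less inhibition and higher numbers for more inhibition at the one concentration tested (going by the name of the read-out)), so far. Compound 1, with the structure `O=C(CCc1cn(C(=O)c2ccccc2)c2ccccc12)N1CCOCC1`, gives 23.4% in this assay. Compound 2, with the structure `COc1ccc2c(c1)c(CCCC(=O)N1CCOCC1)c(C)n2Cc1ccccc1`, gives 54.2% in this assay. Of these two numbers, compound 2 stands highest, and compound 1 is the nearest neighbour, a number lower by a gap that lies beyond the usual scatter of repeated measurements. No single-point change between compound 1 and compound 2 has been worked out, so their two values are all that can be said of them together.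

Compound 3, with the structure `COc1ccc2c(c1)c(CCCC(=O)N1CCOCC1)c(C)n2Cc1ccc(C)cc1`, has not yet been measured in this assay. It differs from compound 2 in one place: methyl in place of hydrogen on an aromatic carbon. Put another way, the benzyl group of compound 2 becomes a 4-methylbenzyl group in compound 3.

Going by the values given here, no measured pair in this set shows what such a change does here. The step from compound 2 to compound 3 in this assay is therefore expected to be small, a number 2.8 percentage points higher from compound 2 to compound 3 (within the scatter), most likely within the scatter, with no clear direction. Compound 3 is thus estimated at 57% in this assay, within a range from 38% to 76%.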

Compound 3, a percentage reported as inhibition, at one concentration (the size of the read-out at that concentration, not a potency): 26.4%
Compound 3: the middle estimate sits 30.6 percentage points above what was measured; the whole stated range lies above it.
By their numbers in this assay, from the lowest: compounds 1 and 3 (each within the scatter of the next); then compound 2.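

Going by these compounds alone, changing benzyl to 4-methylbenzyl gives a number 27.8 percentage points lower from compound 2 to compound 3 (beyond the scatter) in this assay, the first single-place step that can be read in this set. This shows that the aromatic carbon para to a large group on the benzyl ring is not a neutral place in this series: one added methyl, a single heavy atom, is enough to cost a clear part of the inhibition seen at the one concentration tested. Nothing available here offers an explanation for this drop.

The compounds shown leave open whether the loss is particular to methyl or would also appear with a fluorine atom, a chlorine atom or a methoxy group on the same carbon, and whether a hydroxyl group there would behave differently again. They also leave open whether a methyl group on one of the other carbons of this ring would give a similar step, so the result so far describes one group at one place, not the whole ring.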